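This account rests on a few compounds, and the source may have more. Where it says the series, first, only, none or still open, it means among the compounds named here.

Three compounds share one core and differ only in a single aromatic group. Compound 1 `c1ccc2c(-c3cn4ccnc4c(-c4ccc5ncn(C6CCCCC6)c5c4)n3)cccc2c1` carries a naphthalen-1-yl group and in a functional assay on MDA-MB-468 cells (Homo sapiens) for inhibition, read by sulforhodamine B assay, with a stated time of 48 h, tested at 10 uM (a lower number here means less inhibition, a higher number more inhibition at the concentration tested (going by the name of the read-out)), gives 10.4%. Compound 2 `Fc1ccc(-c2cn3ccnc3c(-c3ccc4ncn(C5CCCCC5)c4c3)n2)cc1`, with a 4-fluorophenyl group, gives 19.5%, and compound 3 `Brc1ccc(-c2cn3ccnc3c(-c3ccc4ncn(C5CCCCC5)c4c3)n2)cc1`, with a 4-bromophenyl group, gives 33.7%. Compound 2 stands second highest of the three: the step of a number 9.1 percentage points higher from compound 1 to compound 2 (within the scatter) lies within the scatter, while the step of a number 14.2 percentage points higher from compound 2 to compound 3 (beyond the scatter) lies beyond it and is modest.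

Compound 4 `Fc1ccccc1-c1cn2ccnc2c(-c2ccc3ncn(C4CCCCC4)c3c2)n1` has not yet been measured. It differs from compound 2 in 2-fluorophenyl in place of 4-fluorophenyl on an aromatic carbon. For the measured compounds named here, no measured step moves a single substituent around its ring while keeping the same atoms; the steps of a number 9.1 percentage points higher from compound 1 to compound 2 (within the scatter) and a number 14.2 percentage points higher from compound 2 to compound 3 (beyond the scatter) each exchange the group itself, and even the larger of them is only modest. Given that compound 2 gives 19.5% and that the change keeps every atom, the expected step is a number 1.5 percentage points higher from compound 2 to compound 4 (within the scatter), which stays within the scatter. Compound 4 is therefore estimated to give 21%, with a likely range from 6% to 38%.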

Compound 4, a percentage reported as inhibition, at one concentration (the size of the read-out at that concentration, not a potency): 27.6%
Compound 4: middle estimate off by 6.6 percentage points, on the low side, within the range that was stated.
By their numbers in this assay, from the lowest: compounds 1, 2, 4 and 3 (each within the scatter of the next, the first and the last beyond it).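

Placing the fluorine differently on the ring, with every atom kept, gives a number 8.1 percentage points higher from compound 2 to compound 4 (within the scatter) in this assay, so this shift alone does not clearly separate the 2-fluorophenyl and 4-fluorophenyl groups. The 2-fluorophenyl group is also not clearly separated from the 4-bromophenyl group, with a number 6.1 percentage points lower from compound 3 to compound 4 (within the scatter). It does stand apart from the naphthalen-1-yl group, with a number 17.2 percentage points higher from compound 1 to compound 4 (beyond the scatter), a separation that the 4-fluorophenyl group does not reach, so the choice of ring position changes which comparison clears the scatter, though not by a step beyond it.

Nothing available here explains these differences. Still open, on these data alone, is how the same position would respond to a phenyl ring carrying an amine or a carboxylic acid in place of the halogen, or to a 2-bromophenyl group.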